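A Chloro Added to the Benzyl Group of Compound 1

This account rests on a few compounds, and the source may have more. Where it says the series, first, only, none or still open, it means among the compounds named here.

Measured in a functional assay on A2780 cells (Homo sapiens) for antiproliferative activity, read by resazurin assay, with a stated time of 72 h; on this read-out higher numbers stand for weaker inhibition and lower numbers for stronger inhibition:
- compound 1 `CN(Cc1ccccc1Br)C(=O)c1cc2c(Cc3ccccc3)n[nH]c2cc1O`: 1200 nM
- compound 2 `Cc1ccccc1CN(C)C(=O)c1cc2c(Cc3ccccc3)n[nH]c2cc1O`: 4400 nM
- compound 3 `COc1cccc(CN(C)C(=O)c2cc3c(Cc4ccccc4)n[nH]c3cc2O)c1OC`: 4800 nM

Compound 1, at 1200 nM, has the lowest number of the three and so is the strongest inhibitor here. Both other compounds lie modestly above it, as a 3.7-fold higher number from compound 1 to compound 2 (0.56 log units; beyond the scatter) and a 4.0-fold higher number from compound 1 to compound 3 (0.60 log units; beyond the scatter) show, each beyond the scatter. Between the two weaker compounds, a 1.1-fold higher number from compound 2 to compound 3 (0.04 log units; within the scatter) stays within the scatter.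

Compound 4 `CN(Cc1ccccc1Br)C(=O)c1cc2c(Cc3cccc(Cl)c3)n[nH]c2cc1O` keeps the 2-bromophenyl group of compound 1 and changes benzyl to 3-chlorobenzyl: chloro in place of hydrogen on an aromatic carbon. In words, chloro takes the place of hydrogen on an aromatic carbon. Going by the values given here, none of the measured steps touches this site, since all three concern the group on the amide-type nitrogen. They therefore say nothing direct about the direction of the change. They only show that single substitutions in this small series moved the number modestly, as in a 3.7-fold higher number from compound 1 to compound 2 (0.56 log units; beyond the scatter). No clear shift in this assay is therefore expected, with a slight lowering as a weak guess. The estimated step is a 1.2-fold lower number from compound 1 to compound 4 (0.08 log units; within the scatter), which is expected to stay within the usual scatter. For compound 4 the expected value is 1000 nM, with an estimated range of 400 nM to 2800 nM.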

Compound 4, half-maximal inhibitory concentration: 130 nM
For compound 4 the middle estimate is 7.7-fold (0.89 log units) above the measured one, and the stated range ends above it.
By their numbers in this assay, from the lowest: compound 4; then compound 1; then compounds 2 and 3 (each within the scatter of the next).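

In this assay, putting chloro in place of hydrogen on the benzyl group of compound 1, to give 3-chlorobenzyl, brought a 9.2-fold lower number from compound 1 to compound 4 (0.97 log units; beyond the scatter) and showed that the number responds to a change at this site. The earlier compounds shown here could not show this, as all of their steps concerned the group on the amide-type nitrogen, and both steps away from the 2-bromophenyl group of compound 1 raised the number, as in a 3.7-fold higher number from compound 1 to compound 2 (0.56 log units; beyond the scatter) and a 4.0-fold higher number from compound 1 to compound 3 (0.60 log units; beyond the scatter), whereas this single added chlorine lowered it. No measurement among the material shown accounts for the lowering, so its cause remains unknown.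

A single compound leaves open whether the lowering is particular to chloro, and whether a methoxy group, an amine or a carboxylic acid at the same place on the ring would move the number in the same direction. Going by these compounds, it also remains open whether chloro elsewhere on this ring would do the same, and whether 3-chlorobenzyl would bring a similar step when paired with the 2-methylphenyl group of compound 2 or the 2,3-dimethoxyphenyl group of compound 3.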